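Methyl in place of (oxiran-2-yl)methoxy on the shared core

A few compounds are considered here, and "the series" means these few. Any claim that something is new, unique, unknown or untested is made for them only; others in the source may bear on it.

Compound 1 (`CSc1ccc(C2=C(c3ccc(O)c(O)c3)C(=O)N3CCCC3C2)cc1`) gives 80000 nM in a functional assay on SK-OV-3 cells (Homo sapiens) for cytotoxicity (a higher number here means a weaker inhibitor of growth, a lower number a stronger inhibitor of growth), and sits above compound 2 (`CSc1ccc(C2=C(c3ccc(OCC4CO4)cc3)C(=O)N3CCCC3C2)cc1`), which gives 10000 nM as the lower of the two numbers, a gap beyond the scatter. Compound 3 (`CSc1ccc(C2=C(c3ccc(C)cc3)C(=O)N3CCCC3C2)cc1`) is still unmeasured. Relative to compound 2, it has methyl in place of (oxiran-2-yl)methoxy on an aromatic carbon, para to a large group (methyl in place of (oxiran-2-yl)methoxy on an aromatic carbon). What this change does in this assay remains unshown by any measured pair differing in one place. A step of modest size is expected, toward a higher number and so a weaker inhibitor of growth. The support for this is thin: compound 2 at 10000 nM is the lowest number in hand, and compound 1 at 80000 nM is the only other reference, so a further fall seems the less likely outcome. The expected step is a 2.5-fold higher number from compound 2 to compound 3 (0.40 log units; beyond the scatter) and it remains an estimate resting on two values. For compound 3 the estimated value is 25000 nM with a range from 6000 nM to 90000 nM in the same read-out.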

Compound 3, concentration for 50% growth inhibition: 9000 nM
Compound 3: middle estimate off by 2.8-fold (0.44 log units), on the high side; the range from low to high includes it.
By their numbers in this assay, from the lowest: compounds 3 and 2 (each within the scatter of the next); then compound 1.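

In this assay, the first pair differing in one place gives a flat result (a 1.1-fold lower number from compound 2 to compound 3 (0.05 log units; within the scatter)): methyl in place of (oxiran-2-yl)methoxy on an aromatic carbon, para to a large group, stays within the scatter, so in this pair the three-membered ring and its oxygen atoms bring no measurable gain in growth inhibition over a single carbon. By contrast, 4-methylphenyl in place of 3,4-dihydroxyphenyl on a double-bonded ring carbon gives a step beyond the scatter (an 8.9-fold lower number from compound 1 to compound 3 (0.95 log units; beyond the scatter)), which shows that the read-out does respond to a change in the aryl group at that carbon. Nothing in hand gives a reason for either the flat step or the larger one.

Still open, from the compounds shown here alone, is whether an amine or a carboxylic acid, directly on the same aromatic carbon or at the end of a longer chain, would move the read-out beyond the scatter, since the two groups compared there do not separate. Also open is whether a single hydroxy group would behave like methyl or like the 3,4-dihydroxyphenyl arrangement, and how far any of these compounds could move from the micromolar range.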